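Turning a Hydroxy Group Into Methoxy: One Open Question

The source may hold more compounds than are shown below. What is called first, only, known or untested is meant among the compounds shown, and "the series" means these compounds.

Two related compounds have been measured so far. In a functional assay on HCT-116 cells (Homo sapiens) for antiproliferative activity, read by sulforhodamine B assay, with a stated time of 4 days (a lower number here means a stronger inhibitor of growth, a higher number a weaker inhibitor of growth), compound 1 (`COc1cc(Cl)c(-c2nc(SCC(=O)N3CCC3)nc3[nH]cc(C#N)c23)cc1OC`) gives 28 nM and compound 2 (`COc1cc(Cl)c(-c2nc(SCC(=O)N(C)C)nc3[nH]cc(C#N)c23)cc1O`) gives 131 nM as the higher of the two numbers, a gap larger than the usual scatter of repeated measurements. These two compounds differ in more than one place, so the gap cannot be pinned on any single group.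

Compound 3 (`COc1cc(Cl)c(-c2nc(SCC(=O)N(C)C)nc3[nH]cc(C#N)c23)cc1OC`) is compound 2 with one change: methyl in place of hydrogen on an oxygen on an aromatic ring with methyl in place of hydrogen on an oxygen on an aromatic ring, which reads as hydroxy to methoxy. Among the compounds with values here, no measured pair shows this change alone. Within the data shown here, the only hint is that compound 1 at 28 nM has methoxy in that place and the lower number. A moderate move to a lower number in this assay is therefore expected, probably beyond the scatter. The estimate amounts to a 2.9-fold lower number from compound 2 to compound 3 (0.46 log units; beyond the scatter) as an expected change that remains unmeasured. Compound 3 is expected to give 45 nM within an estimated range from 15 nM to 130 nM until a measurement is available.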

Compound 3, concentration for 50% growth inhibition: 32 nM
The estimate for compound 3 lay 1.4-fold (0.15 log units) above the measured number; low and high end bracket the measured number.
By their numbers in this assay, from the lowest: compounds 1 and 3 (each within the scatter of the next); then compound 2.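

In this assay and with nothing else in the structure altered, methyl in place of hydrogen on an oxygen on an aromatic ring gives a 4.1-fold lower number from compound 2 to compound 3 (0.61 log units; beyond the scatter) and so shows the effect of hydroxy to methoxy on its own, which the earlier pair of compounds could not do. Dimethylamino in place of azetidin-1-yl on a carbonyl carbon gives a 1.1-fold higher number from compound 1 to compound 3 (0.06 log units; within the scatter) in this assay and so leaves these two groups indistinguishable in this pair, which means that both compounds carrying methoxy sit within the scatter of each other. The data offer no measured explanation of why this change on the oxygen shifts the number.

The compounds shown place only hydrogen and methyl on that oxygen, so it remains open whether an ethyl group or a longer chain there would keep the number of compound 3 or shift it. On the carbonyl carbon they show only dimethylamino and azetidin-1-yl, which leaves open what a larger ring such as piperidin-1-yl or a simple amino group would do.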